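A Nitro Group Added to Compound 2

A few compounds are considered here, and "the series" means these few. Any claim that something is new, unique, unknown or untested is made for them only; others in the source may bear on it.

In a functional assay on Bel-7402 cells (Homo sapiens) for inhibition, read by MTT assay, with a stated time of 24 h, tested at 10 ug/mL (on this read-out higher numbers stand for more inhibition of growth at the one concentration tested and lower numbers for less inhibition of growth), compound 2 (`O=C(CCCCC1CCSS1)Nc1cccc(C(F)(F)F)c1`) gives 4.43% and compound 1 (`O=C(CCCCC1CCSS1)NO`) gives 11.8% and the two stand within the usual scatter of each other. Compound 3 (`O=C(CCCCC1CCSS1)Nc1ccc([N+](=O)[O-])c(C(F)(F)F)c1`) carries nitro in place of hydrogen on an aromatic carbon ortho to a trifluoromethyl group and para to a large group. Within the data shown here, no measured step of this kind is available, so only a small upward change is expected in this assay with an estimated step of a number 5.6 percentage points higher from compound 2 to compound 3 (within the scatter) that stays within the scatter. For compound 3 the estimated value is 10% with an expected range from 3% to 25% in this measurement.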

Compound 3, percent growth inhibition at one concentration: "not active" (no number reported)
For compound 3 the study gives words and no number; there is nothing to compare the estimate with.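

Among these compounds, compound 3 is reported in this assay only as not active, without a number, so no step from compound 2 to compound 3 can be read. Nothing shown bears on a cause for this result. The compounds shown leave open how far nitro in place of hydrogen shifts growth inhibition in this assay.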